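Swapping Fluoro for Chloro on the Fused Ring

The source may report more compounds than this note shows. Statements on the series, on what has been measured and on what is new or still open speak of the compounds shown alone.

Compound 1 `O=C(Nc1nc2ccc(Cl)cc2s1)c1cn(-c2ccccc2)nc1-c1ccc(F)cc1` gives 3170 nM in a functional assay on PC-3 cells (Homo sapiens) for cytotoxicity, read by MTT assay, with a stated time of 72 h; a lower number here means a stronger inhibitor, a higher number a weaker inhibitor.
Compound 2 `O=C(Nc1nc2ccccc2s1)c1cn(-c2ccccc2)nc1-c1ccc(Cl)cc1` gives 7750 nM in this assay.
Compound 3 `O=C(Nc1nc2ccc(F)cc2s1)c1cn(-c2ccccc2)nc1-c1ccc(Cl)cc1` gives 5790 nM in this assay.

The value of compound 3 lies within the usual scatter of both compound 2 and compound 1, so no ranking among the three can be drawn. Compound 4 `O=C(Nc1nc2ccc(Cl)cc2s1)c1cn(-c2ccccc2)nc1-c1ccc(Cl)cc1` differs from compound 3 by chloro in place of fluoro on an aromatic carbon. Among the compounds with values here, no measured pair shows this exact exchange. Within the data shown here, the one single-point step known, a 1.3-fold lower number from compound 2 to compound 3 (0.13 log units; within the scatter), was small, and compound 1 and compound 3, which differ at two places, also sit within scatter of each other. Compound 4 is therefore expected to give about 4200 nM in this assay, with a range from 1800 nM to 9500 nM. That estimate amounts to an expected 1.4-fold lower number from compound 3 to compound 4 (0.14 log units; within the scatter).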

Compound 4, half-maximal inhibitory concentration: 3230 nM
Compound 4: the middle estimate sits 1.3-fold (0.11 log units) above what was measured, and the stated range covers the measured number.
By their numbers in this assay, from the lowest: compounds 1, 4, 3 and 2 (each within the scatter of the next, the first and the last beyond it).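

Chloro in place of hydrogen at this position gives the first step here that lies beyond the scatter, a 2.4-fold lower number from compound 2 to compound 4 (0.38 log units; beyond the scatter), in this assay, whereas fluoro at the same place did not. Even so, the direct exchange, a 1.8-fold lower number from compound 3 to compound 4 (0.25 log units; within the scatter), stays within the scatter, so chloro and fluoro cannot be told apart at this position. The same exchange at a different aromatic carbon, a 1.0-fold higher number from compound 1 to compound 4 (0.01 log units; within the scatter), also stays within the scatter. No measured evidence accounts for these numbers. On these data alone, how a methoxy group, an amine or a carboxylic acid would behave at this position remains open.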